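A few compounds are considered here, and "the series" means these few. Any claim that something is new, unique, unknown or untested is made for them only; others in the source may bear on it.

Three compounds of the series have numbers in a functional assay on HL-60 cells (Homo sapiens) for cytotoxicity, read by MTT assay, with a stated time of 24 h; on this read-out higher numbers stand for weaker inhibition and lower numbers for stronger inhibition. Compound 3 `COc1c(Br)cc(Br)cc1Oc1ccc(Br)cc1Br` gives 28.2 ug/mL; compound 1 `COc1ccccc1N1CCN(CCCCCOc2c(Br)cc(Br)cc2Oc2ccc(Br)cc2Br)CC1` gives 32.2 ug/mL and compound 2 `Brc1ccc(Oc2cc(Br)cc(Br)c2OCCCCCN2CCN(C/C=C/c3ccccc3)CC2)c(Br)c1` gives 47.2 ug/mL, and all three lie within the scatter of one another. Among the measured compounds shown here, the only measured step, a 1.5-fold higher number from compound 1 to compound 2 (0.17 log units; within the scatter), changes the group on the ring amine at the far end of the chain and not the chain on the aryl oxygen, so it bears on the present change only loosely. Compound 4 `BrCCCCCOc1c(Br)cc(Br)cc1Oc1ccc(Br)cc1Br` differs from compound 3 by 4-bromobutyl in place of hydrogen on a saturated chain carbon bound to an oxygen on an aromatic ring. Compounds 1 and 2 show that a long chain on that oxygen leaves the number near that of compound 3, so the step of a 1.1-fold higher number from compound 3 to compound 4 (0.03 log units; within the scatter) is expected to stay within the scatter. Compound 4 is estimated at 30 ug/mL, in the range 14 ug/mL to 65 ug/mL.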

Compound 4, half-maximal inhibitory concentration: 25.7 ug/mL
For compound 4 the middle estimate is 1.2-fold (0.07 log units) above the measured one; measured number inside the range.
By their numbers in this assay, from the lowest: compounds 4, 3, 1 and 2 (each within the scatter of the next).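

In this assay, among the compounds shown here, the change of methoxy to (5-bromopentyl)oxy reads directly as a 1.1-fold lower number from compound 3 to compound 4 (0.04 log units; within the scatter) and gives the first measured step at this position. The 4-bromobutyl group carries no ring amine at its end, so on this pair the added chain alone leaves the number within the scatter. Nothing at hand gives a cause for this result. Open, as far as these compounds go, is whether a shorter chain, or one ending in a hydroxyl group or a carboxylic acid, would also stay within the scatter. A single cell line also leaves open whether this holds in other cells.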